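Triazole carboxamide series: filling the open ring carbon

The compounds below may be only part of what the source reports. "The series", "measured", "known", "first", "only" and "open" are said of these compounds alone.

Measured so far:
compound 1 `C[C@H](NC(=O)c1cnnn1Cc1ccc(C(F)(F)F)cc1)c1ccc(C(=O)O)cc1` — > 10000 nM
compound 2 `COc1ccc(Cn2nnc(-c3ccccc3)c2C(=O)N[C@@H](C)c2ccc(C(=O)O)cc2)cc1` — 9.3 nM

The two compounds share an acid-bearing amide arm on a triazole core and were tested in a functional assay on CHO cells for antagonist activity at prostaglandin E2 receptor EP4 subtype (Homo sapiens), read by calcium flux, with a stated time of 15 min; on this read-out higher numbers stand for weaker inhibition and lower numbers for stronger inhibition. Compound 1 gives only a limit in this assay, > 10000 nM, so no number is known for it. Compound 2 reaches 9.3 nM in this assay. Within the data shown here, the record of compound 1 is summarised by the limit of > 10000 nM in this assay, at which 1 of the 2 values shown sits; compound 1 stands at the weak end of what has been seen, while compound 2 shows strong inhibition, and no single-change step connects the two.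

Compound 3 `C[C@H](NC(=O)c1c(C2CCCC2)nnn1Cc1ccc(C(F)(F)F)cc1)c1ccc(C(=O)O)cc1` is the next member. It differs from compound 1 in one place: cyclopentyl in place of hydrogen on an aromatic carbon. Among the measured compounds shown here, since no measured step of one change is available, the size of the move is open, but the gap between compound 1 and compound 2 shows that a substituted ring carbon is compatible with strong inhibition.

Compound 3 is expected to move well beyond the scatter toward stronger inhibition, a step of an at least 160-fold lower number from compound 1 to compound 3 (2.22 log units; beyond the scatter) from compound 1. Compound 3 is estimated at 60 nM, within 8 nM to 600 nM.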

Compound 3, half-maximal inhibitory concentration: 65.1 nM
Beside the measured number, compound 3's estimate is 1.1-fold (0.04 log units) below it; low and high end bracket the measured number.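

In this assay, among these compounds, cyclopentyl in place of hydrogen on the open aromatic carbon gives an at least 150-fold lower number from compound 1 to compound 3 (2.18 log units; beyond the scatter), the first single-change reading at this position. With the 4-(trifluoromethyl)benzyl group and the acid-bearing amide arm held fixed, this carbon is shown not to be a neutral site: a carbon-only ring with no hydrogen-bond donors or acceptors is enough to turn a compound without a measurable number into one with a clear value. Compound 1 is recorded only as a limit, so the step has a floor but no measured upper end, and its true size stays unknown: the limit of > 10000 nM in this assay, at which 1 of the 3 values shown sits.

The compounds shown do not tell whether the gain follows the size or the shape of the group on this carbon, which a methyl, an isopropyl or a cyclohexyl ring would begin to separate, or whether it survives a heteroatom, as in a tetrahydropyranyl ring or an amine. Among the compounds shown here, they also leave open whether cyclopentyl gives a similar gain when the 4-(trifluoromethyl)benzyl group is replaced, since no single-change pair yet tests the two sites together.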